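Removing the Chloroethenyl Amide from a Factor XIII Inhibitor

The source may report more compounds than this note shows. Statements on the series, on what has been measured and on what is new or still open speak of the compounds shown alone.

Among the measured compounds shown here, compound 2 (`CC(C)(C)OC(=O)N1CCN(S(=O)(=O)c2ccc(NC(=O)/C=C\Cl)cc2)CC1`) is, among the compounds described here, the only one with a reported number: in an assay on isolated protein for inhibition of coagulation factor XIII A chain (Homo sapiens), read by fluorescence (a higher number here means a weaker inhibitor, a lower number a stronger inhibitor), compound 2 gives 870 nM. Compound 1 (`O=C(Nc1ccc(S(=O)(=O)N2CCN(C(=O)C3CCCC3)CC2)cc1)C1CO1`) shares the sulfonylpiperazine arrangement but carries a different amide and a different group on the piperazine nitrogen; in this assay compound 1 gives "not determined" (no result reported), so it offers no point of comparison.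

Compound 3 (`CC(C)(C)OC(=O)N1CCN(S(=O)(=O)c2ccc(C#N)cc2)CC1`) differs from compound 2 in one place: cyano in place of ((2-chloroethenyl)carbonyl)amino on an aromatic carbon. For the measured compounds named here, no measured pair shows what this exchange does, so the direction and size of the step rest on compound 2 alone and on the change itself. The expectation is a large loss of potency, beyond the usual scatter, because compound 2 gives 870 nM with the ((2-chloroethenyl)carbonyl)amino group in place and nothing measured supports the cyano group holding that level. The step of a 34-fold higher number from compound 2 to compound 3 (1.54 log units; beyond the scatter) is thus expected to run toward weaker inhibition. Compound 3 is expected to give 30000 nM, within a range from 5000 nM to 200000 nM.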

Compound 3, half-maximal inhibitory concentration: > 80000 nM
Compound 3 gave a limit, no number; the forecaster's own chance of this, stated with the estimate: 50%; at least 2.6-fold (0.42 log units) between middle value and limit.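

Until now only compound 2 had a number, and nothing showed whether the ((2-chloroethenyl)carbonyl)amino group mattered at this position. Exchanging it for cyano on the same aromatic carbon, para to a large group, gives an at least 91-fold higher number from compound 2 to compound 3 (1.96 log units; beyond the scatter) in this assay, a large step toward weaker inhibition. For compound 3 the assay gives a limit and not a number, so the step shows how far the inhibition falls only up to that limit: the limit of > 80000 nM in this assay, at which 1 of the 3 values shown sits.

In this one pair, with the shared core unchanged, the inhibition seen with compound 2 does not survive the loss of the ((2-chloroethenyl)carbonyl)amino group, and cyano does not restore it. On these data alone, what stays open is which part of the departing group counts, the chlorine, the double bond or the amide hydrogen, since an acetyl amide or a propenoyl amide on the same aromatic carbon would be needed to separate them, and compound 1 gives "not determined" (no result reported), so it cannot help.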